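A few compounds are considered here, and "the series" means these few. Any claim that something is new, unique, unknown or untested is made for them only; others in the source may bear on it.

Compound 1 `C#CC#CCCCC#CC#C/C=C\CCCC/C=C\C#C`: in a functional assay on the whole organism with Amphibalanus amphitrite as the target (on this read-out lower numbers stand for an effect already at smaller amounts and higher numbers for an effect only at larger amounts of compound), compound 1 gives 0.25 ug/mL.
Compound 2 `C#C/C=C\CCCC/C=C\C#CC#CCCCC#CC#C[C@@H](O)CO`: in this assay compound 2 gives 0.25 ug/mL.
Compound 3 `C#C/C=C\CCCC(O)/C=C\C#CC#CCCCC#CC#CC(O)CO`: in this assay compound 3 gives 1.3 ug/mL.

Compound 3 has the highest number of the three, so it needs the largest amount to reach the half-maximal effect. Its gap to compound 1 and its gap to compound 2 are each beyond the usual scatter of this assay, so the difference counts as real. Compound 1 and compound 2 are within the scatter of each other, and the one shown step between them, no change at the digits printed from compound 1 to compound 2 (within the scatter), confirms that attaching the 1,2-dihydroxyethyl group to a triple-bonded carbon left the read-out unchanged.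

Compound 4 `C#C/C=C\CCCC(O)/C=C/C#CC#CCCCC#CC#CC(O)CO` differs from compound 3 only in geometry: the two compounds have the same atoms and bonds; at least one stereo element is drawn with a configuration in one of them and without one in the other: 1 of 4 stereo elements differ; a double bond is drawn Z in compound 3 and E in compound 4. None of the measured steps involves a change in the drawn configuration of a double bond, so no shown step bears directly on this change. With nothing to anchor a direction, the expectation is a step of no change at the digits printed from compound 3 to compound 4 (within the scatter), that is no movement beyond the scatter. Compound 4 is therefore estimated at 1.3 ug/mL, with a range from 0.5 ug/mL to 3.5 ug/mL.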

Compound 4, concentration for half-maximal effect: 0.13 ug/mL
Beside the measured number, compound 4's estimate is 10-fold (1.00 log units) above it, outside the stated range (below it).
By their numbers in this assay, from the lowest: compounds 4, 1 and 2 (each within the scatter of the next); then compound 3.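

Until now the compounds showed only what happens when a group is added, and they said nothing about the shape of the chain itself. Here no atom enters or leaves, yet turning one double bond from Z to E gives a 10-fold lower number from compound 3 to compound 4 (1.00 log units; beyond the scatter), so in this assay the spatial arrangement at this double bond matters on its own, with the atoms and their connections unchanged. Any reading of this single pair as a pure Z to E effect has to carry one caution, since the two drawings are not equally defined: the fact that one of compounds 3 and 4 is drawn with a defined configuration and the other without, at the place where they differ

As far as these compounds go, it remains open whether the other double bond, drawn Z in both compound 3 and compound 4, would respond in the same way to a change to E. It is also open whether the E double bond would give a similar step if the hydroxyl groups were replaced by another group, such as an amine or a methyl ether.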